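Swapping 3-bromophenyl for 2,4-dichlorophenyl: an expected cytotoxicity

The source may hold more compounds than are shown below. What is called first, only, known or untested is meant among the compounds shown, and "the series" means these compounds.

Two related compounds have been tested so far in an ADME assay on NHDF cells (Homo sapiens) for cytotoxicity, read by MTT assay, with a stated time of 72 h (on this read-out lower numbers stand for stronger inhibition and higher numbers for weaker inhibition), and only one of them returned a number. Compound 1 `COc1cccc(/C=C2\CCC/C(=C\c3ccccc3Br)C2=O)c1OC` gives > 50000 nM here, which is a limit of the assay and not a number. Among the compounds with values here, compound 2 `COc1ccc(/C=C2\CCC/C(=C\c3cccc(Br)c3)C2=O)cc1OC` gives 12400 nM as the only actual number available, so it has no measured neighbour against which to be ranked. Compound 3 `COc1ccc(/C=C2\CCC/C(=C\c3ccc(Cl)cc3Cl)C2=O)cc1OC` has not yet been measured. The change 2,4-dichlorophenyl in place of 3-bromophenyl on a double-bonded chain carbon bound to a double-bonded ring carbon puts 2,4-dichlorophenyl in place of 3-bromophenyl on a double-bonded chain carbon bound to a double-bonded ring carbon of compound 2. Within the data shown here, no measured pair differing in one place is available to size such a change, so compound 2 at 12400 nM remains the sole anchor. In this assay the expected shift is none beyond the usual scatter, and no firm direction can be expected. The estimated step of a 1.2-fold higher number from compound 2 to compound 3 (0.08 log units; within the scatter) is correspondingly small. For compound 3 the estimated value is 15000 nM with 5000 nM to 45000 nM as its expected range.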

Compound 3, half-maximal inhibitory concentration: > 50000 nM
Compound 3 ended at the assay's limit; the forecaster's own chance of this, stated with the estimate: 20%; at least 3.3-fold (0.52 log units) between middle value and limit.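

In this assay, the place on a double-bonded chain carbon bound to a double-bonded ring carbon now has its first sized change, as 2,4-dichlorophenyl in place of 3-bromophenyl gives an at least 4.0-fold higher number from compound 2 to compound 3 (0.60 log units; beyond the scatter). Compound 3 gives > 50000 nM, which is a limit of the assay and not a number. The aryl group at this position therefore matters in this read-out, since the change moves the value beyond the scatter, but the full size of the step stays unknown and only its lower bound can be read, because the assay's limit caps what can be seen: the limit of > 50000 nM in this assay, at which 2 of the 3 values shown sit.

The compounds shown leave open whether the higher number goes with the loss of the bromine, the arrival of the two chlorines or the places those atoms take on the phenyl ring, as this single change alters all of them together. From the compounds shown here alone, it is also open whether an amine or a carboxylic acid on that phenyl ring would keep the value at the limit or bring it back into the measurable range.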